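The source may report more compounds than this note shows. Statements on the series, on what has been measured and on what is new or still open speak of the compounds shown alone.

Compound 1 `N#CC1(NC(=O)[C@@H]2C[C@@H](S(=O)(=O)c3ccccc3)C[C@H]2C(=O)N2CC3(COC3)C2)CC1`: 248 nM
Compound 2 `N#CC1(NC(=O)[C@@H]2C[C@@H](S(=O)(=O)c3ccccc3)C[C@H]2C(=O)N2CCCCC2)CC1`: 5 nM
Compound 3 `N#CC1(NC(=O)[C@@H]2C[C@@H](S(=O)(=O)c3ccccc3)C[C@H]2C(=O)N2CCS(=O)(=O)CC2)CC1`: 816 nM

In a functional assay on A20 cells (Mus musculus) for inhibition, with stated times of 1 h, 16 h and 24 h (a higher number here means a weaker inhibitor, a lower number a stronger inhibitor), compound 3 stands at 816 nM and has the highest number of the three, which makes it the weakest inhibitor among them. Compound 4 `N#CC1(NC(=O)[C@@H]2C[C@@H](S(=O)(=O)c3ccccc3)C[C@H]2C(=O)N2CCCC2)CC1` keeps the shared core and differs from compound 3 in one place only: pyrrolidin-1-yl in place of 1,1-dioxothiomorpholin-4-yl on a carbonyl carbon with pyrrolidin-1-yl in place of 1,1-dioxothiomorpholin-4-yl on a carbonyl carbon.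

The step that bears most closely on this is a 160-fold higher number from compound 2 to compound 3 (2.21 log units; beyond the scatter) and it is large. There, compound 2 at 5 nM carries piperidin-1-yl, which like pyrrolidin-1-yl is a non-aromatic ring with 1 hetero atom. Two further steps give the context: a 50-fold lower number from compound 1 to compound 2 (1.70 log units; beyond the scatter) is also large, while a 3.3-fold higher number from compound 1 to compound 3 (0.52 log units; beyond the scatter) is modest, and compound 1 at 248 nM lies between the other two. From the compounds shown here alone, no five-membered ring has been measured, so the effect of ring size remains open. A large step to a lower number is therefore expected, estimated as a 54-fold lower number from compound 3 to compound 4 (1.74 log units; beyond the scatter) and falling somewhat short of the full drop seen with compound 2. For compound 4 the estimated value is 15 nM with an expected range from 4 nM to 70 nM.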

Compound 4, half-maximal inhibitory concentration: 29 nM
Beside the measured number, compound 4's estimate is 1.9-fold (0.29 log units) below it, within the range that was stated.
By their numbers in this assay, from the lowest: compound 2; then compound 4; then compound 1; then compound 3.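

In this assay, pyrrolidin-1-yl shows that a low number at this carbonyl carbon is not confined to piperidin-1-yl, giving a 28-fold lower number from compound 3 to compound 4 (1.45 log units; beyond the scatter), a large step, and an 8.6-fold lower number from compound 1 to compound 4 (0.93 log units; beyond the scatter), a modest one. Ring size can now be read for the first time, and it matters: pyrrolidin-1-yl in place of piperidin-1-yl gives a 5.8-fold higher number from compound 2 to compound 4 (0.76 log units; beyond the scatter), a modest step beyond the scatter, so the five-membered ring keeps most, but not all, of what the six-membered ring gives, and compound 2 retains the lowest number of the four. Across these four compounds, the two groups with nitrogen as their only hetero atom hold the two lowest numbers and the two groups that also carry oxygen hold the two highest, with no compound going against this, although four groups are too few to carry the pattern further.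

From the compounds shown here alone, whether the seven-membered azepan-1-yl ring, morpholin-4-yl, or a piperidin-1-yl ring bearing an amine or a carboxylic acid would keep a number as low as that of compound 2 stays open. No measurement in hand accounts for the differences among these groups.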